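From Methyl to Methoxy in the Cyclobutyl Series

The compounds below may be only part of what the source reports. "The series", "measured", "known", "first", "only" and "open" are said of these compounds alone.

In an ADME assay on liver (Mus musculus) for metabolic stability, read by LC-MS, using microsomes and NADPH (on this read-out lower numbers stand for a less stable compound and higher numbers for a more stable compound), two compounds have been measured so far. Compound 1 `Cc1cc(CN(C)C(CC(=O)O)c2ccc(Cl)cc2)ccc1OCCn1c(=O)ccn(C)c1=O` gives 68%, and compound 2 `Cc1cc(CN(C2CCC2)C(CC(=O)O)c2ccc(Cl)cc2)ccc1OCCn1c(=O)ccn(C)c1=O` gives 22%, the lower of the two numbers. Among the compounds with values here, the single measured step, cyclobutyl in place of methyl on an amine nitrogen, is a number 46 percentage points lower from compound 1 to compound 2 (beyond the scatter), a large one and beyond the scatter.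

Compound 3 `COc1cc(CN(C2CCC2)C(CC(=O)O)c2ccc(Cl)cc2)ccc1OCCn1c(=O)ccn(C)c1=O` keeps the cyclobutyl of compound 2 and differs elsewhere: methoxy in place of methyl on an aromatic carbon. This is methoxy in place of methyl on an aromatic carbon, ortho to a large group and meta to a large group. Within the data shown here, no measured step involves a change at that carbon. The step to compound 2 therefore offers no direct guide, although it shows how far one change can move the numbers in this assay. With no evidence for a direction, no step beyond the scatter is expected, and the range is kept wide. The expected change is a number 2 percentage points lower from compound 2 to compound 3 (within the scatter). Compound 3 is estimated at 20%, with an expected range from 7% to 40%.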

Compound 3, percent of the compound remaining: 51%
The estimate for compound 3 lay 31 percentage points below the measured number; measured number outside the range, above it.
By their numbers in this assay, from the lowest: compound 2; then compound 3; then compound 1.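

In this assay, the aromatic carbon that holds methyl in compound 2 proves to be a place where the read-out responds: methoxy in place of methyl there gives a number 29 percentage points higher from compound 2 to compound 3 (beyond the scatter), a modest step but one that stands clear of the usual variation. Within the data shown here, until now the only measured change had been on the amine nitrogen, and it had lowered the number; this step shows that a change elsewhere in the molecule can raise the number while cyclobutyl stays on that nitrogen. Nothing available bears on why the exchange of one group for the other moves the number in this direction.

The compounds shown leave open whether methoxy would give a step of similar size with methyl instead of cyclobutyl on the amine nitrogen, as this change is seen only in the cyclobutyl series. They also leave open how an ethoxy group, a fluorine atom or a hydroxyl group on the same aromatic carbon would compare with methoxy, and whether a longer chain there would keep the higher number.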